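A few compounds are considered here, and "the series" means these few. Any claim that something is new, unique, unknown or untested is made for them only; others in the source may bear on it.

In a toxicity assay on CHO cells (Cricetulus griseus) for cytotoxicity, read by WST assay, with a stated time of 24 h (on this read-out lower numbers stand for stronger inhibition and higher numbers for weaker inhibition), compound 1 `CC(C)=CCCC(C)=CCNCCCN` reads > 150000 nM, which is a limit of the assay and not a number. Compound 2 `CC(C)=CCCC(C)=CCNCCCNCCCCNCCCN` reads > 150000 nM, which is also a limit. For the measured compounds named here, compound 3 `CC(C)=CCC/C(C)=C\CCC(C)=CCNCCCN` gives 32100 nM, the only actual number so far.

Compound 4 `CC(C)=CCC/C(C)=C\CCC(C)=CCNCCCN(C)CCCN` differs from compound 3 in one place: (3-aminopropyl)(methyl)amino in place of amino on a saturated chain carbon, three bonds along the chain from an amine nitrogen. The new group stands on a saturated chain carbon, three bonds along the chain from an amine nitrogen.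

Going by the values given here, only one measured step gives any guide. This is an at least 4.6-fold lower number from compound 1 to compound 3 (0.66 log units; beyond the scatter), which came with 3-methylbut-2-en-1-yl in place of hydrogen on a saturated chain carbon bound to a double-bonded chain carbon. That step lies beyond the scatter, but it concerns a different change, so it sets no size here. Compound 1 and compound 2 sit at the same limit, so that pair yields no size either.

With compound 3 at 32100 nM as the anchor, no step beyond the scatter is expected in this assay. The expected change is a 1.3-fold lower number from compound 3 to compound 4 (0.11 log units; within the scatter). The estimated value for compound 4 is 25000 nM, with an expected range of 8000 nM to 90000 nM.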

Compound 4, half-maximal inhibitory concentration: 10500 nM
Compound 4: the middle estimate sits 2.4-fold (0.38 log units) above what was measured, within the range that was stated.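

In this assay the swap of amino for (3-aminopropyl)(methyl)amino gives a 3.1-fold lower number from compound 3 to compound 4 (0.49 log units; beyond the scatter), so this saturated chain carbon, three bonds along the chain from an amine nitrogen, is a place where a change can move the reading. Lengthening the amine end of compound 3 in this way brought a stronger effect on the cells, not a loss of it. Compound 1 and compound 2 could not show the size of any such change, as each reads only a limit of the assay and not a number: the limit of > 150000 nM in this assay, at which 2 of the 4 values shown sit.

On these data alone, what stays open is which part of the new group carries the step, the methyl on the nitrogen or the aminopropyl arm. A simple dimethylamino group or a longer 4-aminobutyl arm in the same place would start to separate the two.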